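A few compounds are considered here, and "the series" means these few. Any claim that something is new, unique, unknown or untested is made for them only; others in the source may bear on it.

Compound 1 `Fc1ccccc1N1CCN(Cn2nc(-c3ccc4c(c3)OCCO4)oc2=S)CC1` is reported in a functional assay on BGC-823 cells (Homo sapiens) for antiproliferative activity, read by MTT assay, with a stated time of 48 h (a lower number here means a stronger inhibitor, a higher number a weaker inhibitor), only as a limit of the assay: compound 1 gives > 50000 nM.
Compound 2 `COc1ccccc1N1CCN(Cn2nc(-c3ccc4c(c3)OCCO4)oc2=S)CC1` gives 19500 nM in this assay.

Compound 2 thus holds the only number shown; the other value is a limit (the limit of > 50000 nM in this assay, at which 1 of the 2 values shown sits). Compound 3 `Fc1ccc(N2CCN(Cn3nc(-c4ccc5c(c4)OCCO5)oc3=S)CC2)cc1` differs from compound 2 by 4-fluorophenyl in place of 2-methoxyphenyl on an amine nitrogen in a ring. Among the compounds with values here, the single measured step, an at least 2.5-fold lower number from compound 1 to compound 2 (0.40 log units; beyond the scatter), went from fluoro to methoxy and gave a stronger inhibitor; compound 3 reverses that swap, though as 4-fluorophenyl rather than 2-methoxyphenyl, so the match is not exact. A weaker compound is therefore expected. Compound 3 is estimated at 40000 nM (range 15000 nM to 100000 nM), an expected step of a 2.1-fold higher number from compound 2 to compound 3 (0.31 log units; beyond the scatter), with a real chance that only a limit is reported.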

Compound 3, half-maximal inhibitory concentration: > 50000 nM
Compound 3: a limit, no number (the forecaster's own chance of this, stated with the estimate: 45%); at least 1.2-fold (0.09 log units) between middle value and limit.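

Replacing 2-methoxyphenyl with 4-fluorophenyl on the amine nitrogen in the ring gives an at least 2.5-fold higher number from compound 2 to compound 3 (0.40 log units; beyond the scatter). So the fluoro group in this second placement also fails to match the 2-methoxyphenyl compound in this assay. The step between compound 1 and compound 3 cannot be read, and both fluorophenyl compounds rest at a limit, leaving compound 2 alone with a number: the limit of > 50000 nM in this assay, at which 2 of the 3 values shown sit.

From the compounds shown here alone, whether a 4-methoxyphenyl or a plain phenyl on this nitrogen would give a number stays open. So does whether the methoxy group or its placement matters more.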